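Morpholin-4-yl in place of pyridin-3-yl

A few compounds are considered here, and "the series" means these few. Any claim that something is new, unique, unknown or untested is made for them only; others in the source may bear on it.

Measured so far in a functional assay with Oryctolagus cuniculus as the target; a higher number here means a weaker inhibitor, a lower number a stronger inhibitor (the first value is a limit):
- compound 1 `CC/N=C(/N)Nc1nc(-c2ccc(OC)cc2)c(-c2ccc(OC)cc2)s1` gives > 100 nM
- compound 2 `COc1ccc(-c2nc(CNC(=O)c3cccnc3)sc2-c2ccc(OC)cc2)cc1` gives 25 nM

For the measured compounds named here, compound 2 holds the only true number, 25 nM. Compound 1 reads > 100 nM, which is a limit.

Compound 3 `COc1ccc(-c2nc(CNC(=O)N3CCOCC3)sc2-c2ccc(OC)cc2)cc1` differs from compound 2 by morpholin-4-yl in place of pyridin-3-yl on a carbonyl carbon, with morpholin-4-yl in place of pyridin-3-yl on a carbonyl carbon. Going by the values given here, one measured step bears on this: an at least 4.0-fold lower number from compound 1 to compound 2 (0.60 log units; beyond the scatter), which brought in the whole group holding the pyridin-3-yl. It does not test this swap alone, so no change beyond the scatter is expected in this assay, and the uncertainty stays wide. The expected change is a 1.4-fold higher number from compound 2 to compound 3 (0.15 log units; within the scatter). For compound 3 the estimated value is 35 nM, within an expected range of 10 nM to 130 nM.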

Compound 3, half-maximal inhibitory concentration: 660 nM
For compound 3 the middle estimate is 19-fold (1.28 log units) below the measured one; the measured number lies above the stated range.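

On a carbonyl carbon, pyridin-3-yl and morpholin-4-yl have equal counts of heavy atoms and hydrogen-bond acceptors, yet in this assay the swap gives a 26-fold higher number from compound 2 to compound 3 (1.42 log units; beyond the scatter). This position therefore does not treat these two six-membered rings alike, and in this one pair the aromatic ring goes with the lower number. The step from compound 1 to compound 3 cannot be read, since compound 1 holds only a limit: the limit of > 100 nM in this assay, at which 1 of the 3 values shown sits.

Still open, on these data alone, is whether the ring nitrogen of pyridin-3-yl or the aromatic ring itself matters. Phenyl, pyridin-4-yl or piperidin-1-yl on the same carbonyl carbon would help separate the two.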